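Acyl swap on the ester of compound 1: exposure estimate

The compounds below may be only part of what the source reports. "The series", "measured", "known", "first", "only" and "open" are said of these compounds alone.

Compound 1 `COc1ccc2c(c1)C(=O)N(C[C@@]1(c3cc4ncccc4o3)NC(=O)N(COC(=O)C(C)(C)C)C1=O)C2` gives the highest exposure of the three measured compounds in an ADME assay on the whole organism for pharmacokinetics, with Rattus norvegicus as the target, read by LC-MS, at a dose of 10 mg/kg by the oral route (on this read-out lower numbers stand for lower exposure and higher numbers for higher exposure at the dose given), at 6640 ng.h/mL. Compound 2 `CCN1C(=O)N[C@@](CN2Cc3ccc(OC)cc3C2=O)(c2cc3ncccc3o2)C1=O` gives 378 ng.h/mL, and compound 3 `COCCOCCOCCN1C(=O)N[C@@](CN2Cc3ccc(OC)cc3C2=O)(c2cc3ncccc3o2)C1=O` gives 10.8 ng.h/mL. The measured steps are an 18-fold lower number from compound 1 to compound 2 (1.24 log units; beyond the scatter), a 610-fold lower number from compound 1 to compound 3 (2.79 log units; beyond the scatter) and a 35-fold lower number from compound 2 to compound 3 (1.54 log units; beyond the scatter). Compound 4 `COc1ccc2c(c1)C(=O)N(C[C@@]1(c3cc4ncccc4o3)NC(=O)N(COC(=O)c3ccccc3OC(C)=O)C1=O)C2` differs from compound 1 by 2-acetoxyphenyl in place of tert-butyl on a carbonyl carbon. Among the measured compounds shown here, no measured step alters this acyl group; both steps from compound 1 remove the ((tert-butyl)carbonyl)oxy group altogether, and both lowered the number by large margins. Since compound 4 keeps that substituent, only a modest decrease is expected, far short of those steps. For compound 4 the estimate is 2000 ng.h/mL (range 300 ng.h/mL to 8000 ng.h/mL), an expected step of a 3.3-fold lower number from compound 1 to compound 4 (0.52 log units; beyond the scatter).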

Compound 4, area under the concentration-time curve: 2570 ng.h/mL
Estimate against measurement, compound 4: 1.3-fold (0.11 log units) below; the measured number falls inside the stated range.
By their numbers in this assay, from the lowest: compound 3; then compound 2; then compound 4; then compound 1.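

In this assay, this is the only step shown that changes the acyl group while keeping the ester, and (2-acetoxyphenyl)carbonyl in place of (tert-butyl)carbonyl gives a 2.6-fold lower number from compound 1 to compound 4 (0.41 log units; beyond the scatter). That loss is real but much smaller than an 18-fold lower number from compound 1 to compound 2 (1.24 log units; beyond the scatter), where the ester group is removed, so this position accepts a ring-bearing acyl group without a large drop. Nothing available explains the step.

Still open, going by these compounds, is whether an acyl group carrying an amine or a carboxylic acid would hold the number. It is also unknown whether a longer straight alkyl chain on the carbonyl carbon would match tert-butyl.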